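The compounds below may be only part of what the source reports. "The series", "measured", "known", "first", "only" and "open" are said of these compounds alone.

Three compounds of the series have numbers in an in vitro ADME assay on microsomes from liver (Mus musculus) for metabolic stability; on this read-out lower numbers stand for slow clearance and higher numbers for fast clearance. Compound 1 `COCc1nc2nc(C)cc(Nc3ccc(S(F)(F)(F)(F)F)cc3)n2n1` gives 14.3 mL.min-1.g-1, compound 2 `Cc1cc(Nc2ccc(S(F)(F)(F)(F)F)cc2)n2nc(C3CC3)nc2n1` gives 12.6 mL.min-1.g-1 and compound 3 `CCOc1nc2nc(C)cc(Nc3ccc(S(F)(F)(F)(F)F)cc3)n2n1` gives 11.3 mL.min-1.g-1. Compound 3 carries the lowest of the three numbers, yet its steps to the others, a 1.3-fold lower number from compound 1 to compound 3 (0.10 log units; within the scatter) and a 1.1-fold lower number from compound 2 to compound 3 (0.05 log units; within the scatter), lie within the scatter, as does a 1.1-fold lower number from compound 1 to compound 2 (0.05 log units; within the scatter), so the three cannot be separated on this read-out.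

Compound 4 `Cc1cc(Nc2ccc(S(F)(F)(F)(F)F)cc2)n2nc(C(F)(F)F)nc2n1` is the next step from compound 3: trifluoromethyl in place of ethoxy on an aromatic carbon. The group on that aromatic carbon has already been varied across the measured set, from methoxymethyl to cyclopropyl to ethoxy, and each of those exchanges moved the number by less than the scatter. Among the measured compounds shown here, no measured step involves a trifluoromethyl group, so the change to compound 4 is not directly covered; what the data show is that three different groups at that place have given no shift beyond the scatter. On that basis no step beyond the scatter is expected in this assay. The expected step is a 1.0-fold lower number from compound 3 to compound 4 (0.01 log units; within the scatter). For compound 4 the estimated intrinsic clearance is 11 mL.min-1.g-1, with a range from 5.5 mL.min-1.g-1 to 22 mL.min-1.g-1.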

Compound 4, intrinsic clearance in microsomes: < 6 mL.min-1.g-1
Compound 4 was reported as a limit; the forecaster's own chance of this, stated with the estimate: 3%; middle value at least 1.8-fold (0.26 log units) away from the limit.
By their numbers in this assay, from the lowest: compounds 3, 2 and 1 (each within the scatter of the next). At a limit, below all of these: compound 4.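

In this assay the group on this aromatic carbon, between two ring nitrogen atoms, now matters: methoxymethyl, cyclopropyl and ethoxy could not be separated from one another, whereas trifluoromethyl gives an at least 2.3-fold lower number from compound 1 to compound 4 (0.37 log units; beyond the scatter) and an at least 2.1-fold lower number from compound 2 to compound 4 (0.32 log units; beyond the scatter). Against ethoxy the reading is weaker, with an at least 1.8-fold lower number from compound 3 to compound 4 (0.27 log units; that floor lies within the scatter), so that step alone does not establish a change beyond the scatter, and the pattern rests on the other two exchanges. Compound 4 is reported as a limit and not as a number, so all three steps are floors and their full size stays unread: the limit of < 6 mL.min-1.g-1 in this assay, at which 1 of the 4 values shown sits.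

The compounds shown leave open whether this low reading belongs to trifluoromethyl alone or would also appear with other groups at this place, such as a nitrile, a chlorine atom, an amine or a longer fluorinated chain. They also leave open whether the exchange of ethoxy for trifluoromethyl would read the same way if the group on the far aromatic ring were something else, such as a chlorine atom or a methoxy group.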